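The source may hold more compounds than are shown below. What is called first, only, known or untested is meant among the compounds shown, and "the series" means these compounds.

Of the compounds shown here, three have been measured so far. In a functional assay on HT-29 cells (Homo sapiens) for inhibition, read by MTT assay, with a stated time of 72 h (on this read-out lower numbers stand for stronger inhibition and higher numbers for weaker inhibition), compound 1 (`COc1cc(NC(=O)/C=C/c2cccc(OCc3ccccc3)c2)cc(OC)c1OC`) gives 3600 nM, compound 2 (`C=C(Br)C(=O)Nc1cccc(/C=C/C(=O)Nc2cccc3ccccc23)c1`) gives 6500 nM and compound 3 (`C=C(Br)C(=O)Nc1cccc(/C=C/C(=O)Nc2cccc(F)c2)c1`) gives 4600 nM. These three numbers all lie within the usual scatter of one another, so compound 3 cannot be told apart from either of the other two, and no ranking can be drawn from them.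

The next compound to be tested is compound 4 (`C=C(Br)C(=O)Nc1cccc(/C=C/C(=O)Nc2ccc(OC)cc2)c1`), which has not yet been measured. Its structure differs from that of compound 3 in one place, with 4-methoxyphenyl in place of 3-fluorophenyl on an amide-type nitrogen.

Going by the values given here, no pair of measured compounds differs in only one place, so the data offer no direct measure of what such a change does in this assay. Among the compounds with values here, the only guide is the narrow spread of the numbers so far, with compound 2 at 6500 nM and compound 3 at 4600 nM falling within the scatter of each other. On that basis, no shift beyond the scatter is expected in either direction. The estimated step is a 1.2-fold lower number from compound 3 to compound 4 (0.06 log units; within the scatter). The expected value for compound 4 is 4000 nM, with an estimated range from 1500 nM to 10000 nM.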

Compound 4, half-maximal inhibitory concentration: 2300 nM
Estimate against measurement, compound 4: 1.7-fold (0.24 log units) above, and the stated range covers the measured number.
By their numbers in this assay, from the lowest: compounds 4, 1, 3 and 2 (each within the scatter of the next, the first and the last beyond it).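

In this assay, going by these compounds alone, the exchange of 3-fluorophenyl for 4-methoxyphenyl on an amide-type nitrogen gives a 2.0-fold lower number from compound 3 to compound 4 (0.30 log units; within the scatter), and this is the first reading of a change in one place, as no earlier pair offered one. It shows that, on this core, this place accepts a ring carrying a methoxy group instead of one carrying fluorine, with one more heavy atom and one hydrogen-bond acceptor entering, without a shift that can be told from the scatter. Nothing given here accounts for the size of this step.

This single pair cannot separate what leaving fluorine contributes from what entering methoxy contributes, and it cannot show whether the same exchange would read alike on another core. It also leaves open whether a group of a different kind on this amide-type nitrogen, such as an aminophenyl, a carboxylic acid-bearing phenyl or a longer alkyl chain, would give a step that lies beyond the scatter in either direction.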